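Carbamate nitrogen substituents: cyclopentyl to cyclohexyl

The source may hold more compounds than are shown below. What is called first, only, known or untested is meant among the compounds shown, and "the series" means these compounds.

Measured so far in an assay (strain Wistar) for inhibition of Fatty-acid amide hydrolase 1 (Rattus norvegicus); a lower number here means a stronger inhibitor, a higher number a weaker inhibitor:
compound 1 `CCCNC(=O)Oc1cccc(C(=O)c2nc3ccccc3o2)c1` gives 109 nM
compound 2 `CCCCNC(=O)Oc1cccc(C(=O)c2nc3ccccc3o2)c1` gives 54 nM
compound 3 `O=C(NC1CCCC1)Oc1cccc(C(=O)c2nc3ccccc3o2)c1` gives 28 nM

Compound 3 has the lowest number of the three; its gap to compound 2 is within the scatter, whereas the other gap is beyond it (a 3.9-fold lower number from compound 1 to compound 3 (0.59 log units; beyond the scatter)). Compound 4 `O=C(NC1CCCCC1)Oc1cccc(C(=O)c2nc3ccccc3o2)c1` is not yet measured; it differs from compound 3 by cyclohexyl in place of cyclopentyl on an amide-type nitrogen. Within the data shown here, the steps that bear on it are the earlier changes at the same nitrogen: a 2.0-fold lower number from compound 1 to compound 2 (0.31 log units; beyond the scatter), a 3.9-fold lower number from compound 1 to compound 3 (0.59 log units; beyond the scatter) and a 1.9-fold lower number from compound 2 to compound 3 (0.29 log units; within the scatter). Among the measured compounds shown here, all are modest, and none enlarges a ring, so the present change has no direct precedent. For compound 4 the expected step is a 1.4-fold lower number from compound 3 to compound 4 (0.15 log units; within the scatter), which is no more than a small shift. Compound 4 is estimated at 20 nM, with a range from 7 nM to 60 nM.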

Compound 4, half-maximal inhibitory concentration: 47 nM
Beside the measured number, compound 4's estimate is 2.4-fold (0.37 log units) below it; low and high end bracket the measured number.
By their numbers in this assay, from the lowest: compounds 3, 4 and 2 (each within the scatter of the next); then compound 1.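

In this assay, among these compounds, the first ring-size change at this amide-type nitrogen gives a 1.7-fold higher number from compound 3 to compound 4 (0.22 log units; within the scatter) and so makes no readable difference, while cyclohexyl also matches butyl, with a 1.1-fold lower number from compound 2 to compound 4 (0.06 log units; within the scatter) as the step. Only propyl stands apart, with a 2.3-fold lower number from compound 1 to compound 4 (0.37 log units; beyond the scatter) as the step, so compound 2, compound 3 and compound 4 cannot be told apart here. Nothing available explains these differences.

Still open, as far as these compounds go, is whether cycloheptyl, phenyl or benzyl on this nitrogen would stay within the same narrow range.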